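A few compounds are considered here, and "the series" means these few. Any claim that something is new, unique, unknown or untested is made for them only; others in the source may bear on it.

Measured so far:
compound 1, `O=C(O)CCC(=O)N(C1CC1)[C@H]1c2ccccc2N(C(=O)c2cccc(OC(F)(F)F)c2)[C@H]2CC[C@H]21`: 18 nM
compound 2, `O=C(O)COC(=O)N(C1CC1)[C@H]1c2ccccc2N(C(=O)c2ccc(F)cc2)[C@H]2CC[C@H]21`: 3.6 nM
compound 3, `O=C(O)CCC(=O)N(C1CC1)[C@H]1c2ccccc2N(C(=O)c2cccc(F)c2)[C@H]2CC[C@H]21`: 14 nM

All three were read in a functional assay for antagonist activity at prostaglandin D2 receptor 2 (Homo sapiens), read by flow cytometry, with stated times of 10 min and 4 min; a lower number here means a stronger inhibitor, a higher number a weaker inhibitor. Compound 2 gives the lowest number of the three; both compound 3 and compound 1 stand beyond the scatter from it. Compound 3 and compound 1 themselves differ by trifluoromethoxy in place of fluoro on an aromatic carbon, and that step was a 1.3-fold higher number from compound 3 to compound 1 (0.11 log units; within the scatter). The cores of compound 2 and compound 3 differ in a way that is not broken down here.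

Compound 4, `O=C(O)COC(=O)N(C1CC1)[C@H]1c2ccccc2N(C(=O)c2ccc(OC(F)(F)F)cc2)[C@H]2CC[C@H]21`, is not yet measured. It differs from compound 2 by trifluoromethoxy in place of fluoro on an aromatic carbon. This is the same kind of change as that from compound 3 to compound 1, not the same: here the entering group sits para to a large group, there it sat meta to a large group. For the measured compounds named here, the step of a 1.3-fold higher number from compound 2 to compound 4 (0.10 log units; within the scatter) is expected, because a 1.3-fold higher number from compound 3 to compound 1 (0.11 log units; within the scatter) lay within the scatter, and the pair of compound 3 and compound 1 is the only measured guide. Compound 4 is therefore estimated at 4.5 nM, with a range from 2 nM to 11 nM.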

Compound 4, half-maximal inhibitory concentration: 8.2 nM
Estimate against measurement, compound 4: 1.8-fold (0.26 log units) below; the measured number falls inside the stated range.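

In this assay, trifluoromethoxy in place of fluoro, para to a large group, gives a 2.3-fold higher number from compound 2 to compound 4 (0.36 log units; beyond the scatter), a modest loss on the core of compound 2. Set beside the earlier step, the same change on the two cores gives results that cannot be told apart: the same change on two cores in this assay, a 1.3-fold higher number (0.11 log units; within the scatter) from compound 3 to compound 1 and a 2.3-fold higher number (0.36 log units; beyond the scatter) from compound 2 to compound 4, 1.8-fold (0.25 log units) apart, within the scatter of two such steps. For the compounds shown here, this agreement rests on only two pairs, which differ both in the core and in where the group sits on the aromatic ring, so it neither shows that the step is constant across the series nor separates any contribution of the core from one of position.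

The compounds shown leave open how other groups at this place would read, such as chloro, methoxy or a nitrile, and whether they would follow the same small step on both cores. Also open, from the compounds shown here alone, is how this change would carry over if the carboxylic acid were replaced by an amide or set on a longer chain.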